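The compounds below may be only part of what the source reports. "The series", "measured", "known", "first", "only" and "open" are said of these compounds alone.

Two amides built on the same core have been tested. Compound 1 `CCCCNC(=O)CC1CCc2cc(OC)c(OC)cc21` carries a butyl group on the amide nitrogen, and in a functional assay on the whole organism (strain Wistar) for inhibition, with Rattus norvegicus as the target, read by paw edema, with stated times of 60 min and 3 h, at a dose of 100 mg/kg by the oral route (on this read-out higher numbers stand for more inhibition at the one dose given (going by the name of the read-out) and lower numbers for less inhibition), compound 1 gives 27.5%. Compound 2 `COc1cc2c(cc1OC)C(CC(=O)NC(C)(C)C)CC2` carries a tert-butyl group in the same place, and in this assay compound 2 gives 33.3%. The step of a number 5.8 percentage points higher from compound 1 to compound 2 (within the scatter) is the only one measured so far, so compound 2 stands together with compound 1 inside the usual scatter, with nothing to set the two apart. Compound 3 `COc1cc2c(cc1OC)C(CC(=O)NCc1ccccc1)CC2` is the next member: benzyl in place of tert-butyl on an amide-type nitrogen. Among the measured compounds shown here, no measured step bears directly on this exchange, since only butyl against tert-butyl has been compared, and that comparison stayed within the scatter. The expected step of a number 3.3 percentage points lower from compound 2 to compound 3 (within the scatter) is therefore set small, with a wide range to allow for the untested benzyl group. For compound 3 the estimate is 30%, between 14% and 46%.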

Compound 3, a percentage reported as inhibition, in the whole organism at one dose (the size of the read-out at that dose, not a potency): 14.5%
Beside the measured number, compound 3's estimate is 15.5 percentage points above it, and the stated range covers the measured number.
By their numbers in this assay, from the lowest: compound 3; then compounds 1 and 2 (each within the scatter of the next).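

In this assay, benzyl in place of tert-butyl on an amide-type nitrogen gives a number 18.8 percentage points lower from compound 2 to compound 3 (beyond the scatter), so the group at this position can change the result by more than the usual scatter, which the butyl and tert-butyl pair did not show. Among the compounds shown here, the comparison with the butyl amide points the same way, with a number 13 percentage points lower from compound 1 to compound 3 (beyond the scatter), so benzyl, the only one of the three groups with a six-membered aromatic ring, stands apart from both open-chain groups. Nothing measured here explains this loss of inhibition.

On these data alone, it remains open whether the aromatic ring itself matters, which a cyclohexylmethyl group in the same place could test. As far as these compounds go, the effect of the chain length linking the ring to the nitrogen is also open, and a 2-phenylethyl group would probe it.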